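A few compounds are considered here, and "the series" means these few. Any claim that something is new, unique, unknown or untested is made for them only; others in the source may bear on it.

Measured so far in this assay:
- compound 1 `CO/C(O)=C1\C(C)=NC(C)=C(C(=O)OCCCN2C(=O)c3ccccc3S2(=O)=O)C1c1cccc([N+](=O)[O-])c1`: 2.6 nM
- compound 2 `CC1=NC(C)=C(C(=O)OCCCN2C(=O)c3ccccc3S2(=O)=O)C(c2cccc([N+](=O)[O-])c2)/C1=C(\O)OC(C)C`: 1 nM
- compound 3 `COCCO/C(O)=C1\C(C)=NC(C)=C(C(=O)OCCCN2C(=O)c3ccccc3S2(=O)=O)C1c1cccc([N+](=O)[O-])c1`: 6.8 nM

In a functional assay (aorta) with Oryctolagus cuniculus as the target (on this read-out lower numbers stand for stronger inhibition and higher numbers for weaker inhibition), compound 3 stands highest of the three numbers; the steps are a 2.6-fold higher number from compound 1 to compound 3 (0.42 log units; beyond the scatter) and a 6.8-fold higher number from compound 2 to compound 3 (0.83 log units; beyond the scatter). Compound 4 `COCCO/C(O)=C1\C(C)=NC(C)=C(C(=O)OCCCN2C(=O)c3ccccc3S2(=O)=O)C1c1ccccc1Cl` differs from compound 3 by 2-chlorophenyl in place of 3-nitrophenyl on a saturated ring carbon. The measured steps, a 2.6-fold lower number from compound 1 to compound 2 (0.41 log units; beyond the scatter), a 2.6-fold higher number from compound 1 to compound 3 (0.42 log units; beyond the scatter) and a 6.8-fold higher number from compound 2 to compound 3 (0.83 log units; beyond the scatter), all concern the group on an oxygen on an unsaturated carbon; none touches the aryl group on the saturated ring carbon, so none bears directly on this change. No direction can be read from the series, and a wide range is needed. The step is estimated as a 1.1-fold lower number from compound 3 to compound 4 (0.05 log units; within the scatter). Compound 4 is therefore expected near 6 nM, within 1 nM to 40 nM.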

Compound 4, half-maximal inhibitory concentration: 2.9 nM
Compound 4: middle estimate off by 2.1-fold (0.32 log units), on the high side; the range from low to high includes it.
By their numbers in this assay, from the lowest: compound 2; then compounds 1 and 4 (each within the scatter of the next); then compound 3.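

In this assay, within the data shown here, the aryl group on the saturated ring carbon proves to be a second place that moves the number, a point the earlier steps on the oxygen-bound group could not show: 2-chlorophenyl in place of 3-nitrophenyl gives a 2.3-fold lower number from compound 3 to compound 4 (0.37 log units; beyond the scatter) and stays a modest change. So 3-nitrophenyl is not required for a value in this range, and 2-chlorophenyl, with no hydrogen-bond acceptors, serves as well or better here.

The swap changes both the substituent and its ring place, so 3-chlorophenyl, 2-nitrophenyl or plain phenyl would be needed to separate the two. No measurement in hand accounts for the step.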